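Aryl substituent swap on the shared core: methyl to hydroxy

A few compounds are considered here, and "the series" means these few. Any claim that something is new, unique, unknown or untested is made for them only; others in the source may bear on it.

Of the compounds shown here, two have been measured in an assay for binding affinity to dual specificity mitogen-activated protein kinase kinase 4 (Homo sapiens), read by KINOMEscan, tested at 100 nM; on this read-out lower numbers stand for a stronger effect and higher numbers for a weaker effect at the one concentration tested. Compound 1 `CCCS(=O)(=O)Nc1ccc(F)c(C(=O)c2n[nH]c3ncc(-c4ccc(F)cc4)cc23)c1F` gives 2.1%. Compound 2 `CCCS(=O)(=O)Nc1ccc(F)c(C(=O)c2n[nH]c3ncc(-c4cccc(C)c4)cc23)c1F` gives 15%. Compound 2 thus stands at the higher of the two numbers, since a number 12.9 percentage points higher from compound 1 to compound 2 (beyond the scatter).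

Compound 3 `CCCS(=O)(=O)Nc1ccc(F)c(C(=O)c2n[nH]c3ncc(-c4cccc(O)c4)cc23)c1F` is not yet measured. The change from compound 2 is hydroxy in place of methyl on an aromatic carbon. For the measured compounds named here, the one measured step, from compound 1 to compound 2, exchanges a whole aryl substituent rather than a single group on the same ring and is of modest size; it bears only loosely on the present change, and nothing measured shows a hydroxy entering or a methyl leaving.

The step to compound 3 in this assay is therefore expected to be small, a number 3 percentage points lower from compound 2 to compound 3 (within the scatter), and could lie within the scatter. Compound 3 is estimated at 12%, within a range from 3% to 35%, the width reflecting the absence of a direct precedent.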

Compound 3, a percentage reported as activity, at one concentration (the size of the read-out at that concentration, not a potency): 2.2%
Beside the measured number, compound 3's estimate is 9.8 percentage points above it, and the stated range ends above it.
By their numbers in this assay, from the lowest: compounds 1 and 3 (each within the scatter of the next); then compound 2.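

In this assay the change of hydroxy in place of methyl gives a number 12.8 percentage points lower from compound 2 to compound 3 (beyond the scatter) and so shows that this place, on an aromatic carbon meta to a large group, responds to a swap of a single group on the same ring; the earlier pair differed by a whole aryl substituent and could not show this. The comparison of the 3-hydroxyphenyl and 4-fluorophenyl compounds gives a number 0.1 percentage points higher from compound 1 to compound 3 (within the scatter) and so leaves no separation between them at the one concentration tested, while the 3-methylphenyl compound remains apart from both by steps beyond the scatter. No measured information bears on why hydroxy and methyl read differently at this place.

The compounds shown leave open how an amine, a methoxy or a carboxylic acid would read at the same carbon, and so whether the result is particular to hydroxy. They also leave open whether hydroxy on another carbon of the ring would give a comparable read-out, and how these single-concentration readings would translate into potency.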